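The source may report more compounds than this note shows. Statements on the series, on what has been measured and on what is new or still open speak of the compounds shown alone.

Compound 1 `O=C1/C(=C/c2cccc(Cl)c2)Cc2ccccc21` and compound 2 `O=C1/C(=C/c2cccc(Br)c2)Cc2ccccc21` share one core; compound 3 `O=C1CCCCC/C1=C\c1ccc(Cl)cc1` and compound 4 `O=C1CCCCC/C1=C\c1ccc(Br)cc1` share another. In a functional assay on MOLT-4 cells (Homo sapiens) for inhibition (on this read-out lower numbers stand for stronger inhibition and higher numbers for weaker inhibition), compound 1 gives 50900 nM, and compound 2 gives 173000 nM. The change between them is bromo in place of chloro on an aromatic carbon, and the measured outcome was a 3.4-fold higher number from compound 1 to compound 2 (0.53 log units; beyond the scatter). Compound 3 gives 52600 nM in this assay; the difference between its core and the core of compound 1 is not broken down here, and the two values lie within the usual scatter of each other. Compound 4 has not yet been measured in this assay. It differs from compound 3 by bromo in place of chloro on an aromatic carbon. This is the same kind of change as the earlier one, though the surroundings differ: the earlier halogen sat meta to a large group, whereas here it sits para to a group of 9 heavy atoms. Among the compounds with values here, it is expected that a 2.5-fold higher number from compound 3 to compound 4 (0.39 log units; beyond the scatter), because a 3.4-fold higher number from compound 1 to compound 2 (0.53 log units; beyond the scatter) is the only guide, with a wide range since the cores differ. Compound 4 is therefore estimated to give 130000 nM in this assay, expected to lie between 50000 nM and 350000 nM.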

Compound 4, half-maximal inhibitory concentration: 49400 nM
Compound 4: middle estimate off by 2.6-fold (0.42 log units), on the high side, and the stated range ends above it.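

In this assay, putting bromo in place of chloro on an aromatic carbon gave a 1.1-fold lower number from compound 3 to compound 4 (0.03 log units; within the scatter), so the two halogens cannot be told apart on this core. Set beside the earlier step, the same change did not carry over from one core to the other: the same change on two cores in this assay, a 3.4-fold higher number (0.53 log units; beyond the scatter) from compound 1 to compound 2 and a 1.1-fold lower number (0.03 log units; within the scatter) from compound 3 to compound 4, 3.6-fold (0.56 log units) apart, beyond the scatter of two such steps. Within the data shown here, this shows that a step measured on one core cannot simply be assumed for the other, but with only two pairs, whose surroundings differ, it does not show what sets the two steps apart or how the change would behave on any further core.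

The compounds shown carry only chloro and bromo in these positions, so it stays open whether a fluoro group or a methoxy group would give similar numbers on the two cores. From the compounds shown here alone, it also stays open whether an amine would show the same dependence on the core.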